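The source may report more compounds than this note shows. Statements on the series, on what has been measured and on what is new or still open speak of the compounds shown alone.

Three compounds share one core, a pyrrolidine-bearing pyridyl ether carrying a second aromatic ring. Compound 1 is `CN1CCC[C@H]1COc1cncc(-c2ccccc2)c1`, compound 2 is `CN1CCC[C@H]1COc1cncc(-c2ccc(F)cc2)c1`, and compound 3 is `CN1CCC[C@H]1COc1cncc(-c2ccc(Cl)cc2)c1`. In an assay on membranes from brain for binding affinity to Neuronal acetylcholine receptor; alpha4/beta2 (Rattus norvegicus) (a higher number here means a weaker inhibitor, a lower number a stronger inhibitor), compound 1 gives 0.11 nM, compound 2 gives 0.11 nM, and compound 3 gives 0.082 nM. The three numbers sit close together: no change at the digits printed from compound 1 to compound 2 (within the scatter), a 1.3-fold lower number from compound 1 to compound 3 (0.13 log units; within the scatter), and a 1.3-fold lower number from compound 2 to compound 3 (0.13 log units; within the scatter). Compound 3 therefore stands level with compounds 1 and 2 in this assay, none of the three separated from another by more than the scatter.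

Compound 4 is `CN1CCC[C@H]1COc1cncc(-c2cncnc2)c1`. The change from compound 3 is pyrimidin-5-yl in place of 4-chlorophenyl on an aromatic carbon. Going by the values given here, the measured steps all concern a hydrogen, fluoro or chloro on the outer ring, and each stayed within the scatter, so they say little about trading the whole ring for one that carries two nitrogen atoms; no measured step speaks directly to that. The expectation for compound 4 is a somewhat higher number in this assay than compound 3, amounting to a 3.7-fold higher number from compound 3 to compound 4 (0.56 log units; beyond the scatter), with wide uncertainty. Compound 4 is estimated at 0.3 nM, in a range from 0.05 nM to 2 nM.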

Compound 4, inhibition constant: 0.37 nM
Estimate against measurement, compound 4: 1.2-fold (0.09 log units) below, within the range that was stated.
By their numbers in this assay, from the lowest: compounds 3, 1 and 2 (each within the scatter of the next); then compound 4.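

Replacing the whole outer ring moves the number where changes to a single substituent on that ring did not: in this assay, pyrimidin-5-yl in place of 4-chlorophenyl gives a 4.5-fold higher number from compound 3 to compound 4 (0.65 log units; beyond the scatter), the same swap against 4-fluorophenyl gives a 3.4-fold higher number from compound 2 to compound 4 (0.53 log units; beyond the scatter), and against phenyl it gives a 3.4-fold higher number from compound 1 to compound 4 (0.53 log units; beyond the scatter). This position, on an aromatic carbon two atoms from the ring nitrogen, therefore registers the identity of the ring itself, even though hydrogen, fluoro and chloro on the outer ring could not be told apart, and the size of the step is modest whichever of the three compounds serves as the starting point. The data shown contain nothing that accounts for this step.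

Pyrimidin-5-yl differs from phenyl by two ring nitrogens at once, so the compounds shown cannot tell what a single ring nitrogen, as in a pyridin-3-yl group, would do on its own. Also open, from the compounds shown here alone, is how an amine or a carboxylic acid on the outer phenyl ring would read in this assay.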